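Second Chloro Added to the Phenyl Ring of Compound 2

The source may hold more compounds than are shown below. What is called first, only, known or untested is meant among the compounds shown, and "the series" means these compounds.

Measured compounds:
compound 1, `CN1CCN(c2nc(-c3ccc(Cl)c(Cl)c3)nc3[nH]cnc23)CC1`: > 80%
compound 2, `CN1CCN(c2nc(-c3cccc(Cl)c3)nc3[nH]cnc23)CC1`: > 80%

In an assay on cells for displacement of a labelled ligand from adenosine receptor A3 (Homo sapiens), read by scintillation counting and radioligand binding, with a stated time of 180 min, tested at 10 uM (a lower number here means less inhibition, a higher number more inhibition at the concentration tested (going by the name of the read-out)), compound 1 gives > 80%, which is a limit of the assay and not a number. Compound 2 gives > 80% in the same assay, again a limit. The step that the two limits leave unreadable from compound 1 to compound 2 therefore cannot be sized, because the limit of > 80% in this assay, at which 2 of the 2 values shown sit, leaves both values at the same edge of the range. Compound 3, `CN1CCN(c2nc(-c3cc(Cl)ccc3Cl)nc3[nH]cnc23)CC1`, differs from compound 2 by chloro in place of hydrogen on an aromatic carbon. Among the measured compounds shown here, the only measured step, a step that the two limits leave unreadable from compound 1 to compound 2, concerns a chloro on the same ring and gives no readable size, so no direction beyond the scatter can be drawn from it. Compound 3 is expected to sit at 85%, in a range from 65% to 97%. The step that the limit leaves unreadable from compound 2 to compound 3 is thus estimated to stay within the scatter, most likely reported again as a limit.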

Compound 3, a percentage reported as inhibition, at one concentration (the size of the read-out at that concentration, not a potency): > 80%
Compound 3: only a limit was reported; the forecaster's own chance of this, stated with the estimate: 65%; the middle value lies beyond the limit too.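

Among the compounds shown here, no step between compound 1, compound 2 and compound 3 can be read in this assay, because all three values are limits of the assay and not numbers: the limit of > 80% in this assay, at which 3 of the 3 values shown sit. The compounds shown leave open whether the 3-chlorophenyl, 3,4-dichlorophenyl and 2,5-dichlorophenyl groups differ in inhibition at all.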